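This account rests on a few compounds, and the source may have more. Where it says the series, first, only, none or still open, it means among the compounds named here.

Working notes on the series.

Compound 1 `COc1ccc(-c2cc(/C=C/C(=O)c3ccc(N)cc3)[nH]n2)cc1` was tested in a functional assay on MDA-MB-468 cells (Homo sapiens) for inhibition, read by sulforhodamine B assay, with a stated time of 48 h (on this read-out lower numbers stand for stronger inhibition of growth and higher numbers for weaker inhibition of growth), and gives 430 nM. Compound 3 `COc1ccc(-c2cc(/C=C/C(=O)c3ccc(N)cc3)[nH]n2)cc1OC` differs from compound 1 in one place, (methoxy in place of hydrogen on an aromatic carbon), and in this assay compound 3 gives 1550 nM; this single change made a 3.6-fold higher number from compound 1 to compound 3 (0.56 log units; beyond the scatter). Compound 2 `COc1ccc(C(=O)/C=C/c2cc(-c3cc(OC)c(OC)c(OC)c3)n[nH]2)cc1OC` carries a different core, and in this assay compound 2 gives 750 nM. The difference between the core of compound 2 and the core of compound 1 is not broken down here, so the two values are simply set side by side: compound 2 and compound 1 lie within the scatter of each other, while compound 2 and compound 3 do not.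

Compound 4 `COc1cc(C(=O)/C=C/c2cc(-c3cc(OC)c(OC)c(OC)c3)n[nH]2)cc(OC)c1OC` has not yet been measured in this assay. It differs from compound 2 in one place, (methoxy in place of hydrogen on an aromatic carbon). Within the data shown here, this is the same kind of change as the one from compound 1 to compound 3, but not the same: in compound 4 the entering methoxy is also meta to a methoxy group, which is not so around the place in compound 3.

Among the measured compounds shown here, the one measured instance of this kind of change, a 3.6-fold higher number from compound 1 to compound 3 (0.56 log units; beyond the scatter), is the only ground for an expectation, and it is taken over with some allowance for the different surroundings; the step from compound 2 to compound 4 is expected to be a 3.1-fold higher number from compound 2 to compound 4 (0.49 log units; beyond the scatter). On that basis compound 4 is estimated at 2300 nM in this assay, with a plausible range from 900 nM to 6000 nM.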

Compound 4, concentration for 50% growth inhibition: 1150 nM
For compound 4 the middle estimate is 2.0-fold (0.30 log units) above the measured one, within the range that was stated.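

In this assay, methoxy in place of hydrogen on an aromatic carbon gives a 1.5-fold higher number from compound 2 to compound 4 (0.19 log units; within the scatter), so on the core of compound 2 this step cannot be told apart from the variation between repeated measurements. The two instances of the change do not differ by more than that variation allows, so the data give no ground for saying that the surroundings of the entering methoxy alter the size of the step: the same change on two cores in this assay, a 3.6-fold higher number (0.56 log units; beyond the scatter) from compound 1 to compound 3 and a 1.5-fold higher number (0.19 log units; within the scatter) from compound 2 to compound 4, 2.4-fold (0.37 log units) apart, within the scatter of two such steps. Among these compounds, this does not show that the step has one fixed size on both cores, as there are only two pairs, one step beyond the scatter and one within it, and two pairs are too few to set a size for the series or to rule out a real difference between the cores.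

Open, as far as these compounds go, is whether a hydroxy group, a chlorine atom or a carboxylic acid entering on an aromatic carbon in the same place would give a step of similar size on both cores. Also open, from the compounds shown here alone, is what the core itself contributes, as compound 1 and compound 2 differ in more than one place and their values can only be set side by side.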